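A few compounds are considered here, and "the series" means these few. Any claim that something is new, unique, unknown or untested is made for them only; others in the source may bear on it.

Measured in a functional assay on the whole organism for antagonist activity, with Mus musculus as the target, in the maximal electroshock model; a lower number here means that less compound is needed, a higher number that more compound is needed for the effect:
Compound 1 `COC(=O)NC1=NC(c2ccccc2C)CN1`: 55 mg/kg
Compound 2 `COC(=O)NC1=NC(c2ccccc2)CN1C`: 107 mg/kg

Among the measured compounds shown here, compound 2 gives the higher of only two numbers, but its value lies within the usual scatter of the value for compound 1, so the data do not separate the two. Compound 3 `COC(=O)NC1=NC(c2ccccc2C)CN1C` is compound 2 with a single change: methyl in place of hydrogen on an aromatic carbon. For the measured compounds named here, no pair of measured compounds isolates this change, so its size in this assay is not known directly. A modest step towards a lower number is expected, probably not beyond the scatter, because compound 1 gives 55 mg/kg with a methyl on its aromatic ring. The expected step is a 1.5-fold lower number from compound 2 to compound 3 (0.18 log units; within the scatter). For compound 3 the estimated value is 70 mg/kg, with an expected range from 30 mg/kg to 160 mg/kg.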

Compound 3, dose for half-maximal effect: 68 mg/kg
The estimate for compound 3 lay 1.0-fold (0.01 log units) above the measured number; the measured number falls inside the stated range.
By their numbers in this assay, from the lowest: compounds 1, 3 and 2 (each within the scatter of the next).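

In this assay the two single changes can now be read on their own: methyl in place of hydrogen on an aromatic carbon, ortho to a large group, gives a 1.6-fold lower number from compound 2 to compound 3 (0.20 log units; within the scatter) and methyl in place of hydrogen on an amine nitrogen in a ring gives a 1.2-fold higher number from compound 1 to compound 3 (0.09 log units; within the scatter). Neither step separates the two compounds it joins, so the data resolve no effect of a methyl at either place. Nothing measured here bears on the reason for these small steps.

Going by these compounds, whether a chlorine or a methoxy group on the aromatic carbon, or an ethyl or longer chain on the amine nitrogen in a ring, would give a step beyond the scatter stays open. On these data alone, the effect of a methyl on the other carbons of the aromatic ring also stays open.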